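Methyl on the Seven-Membered Ring of Compound 1

The compounds below may be only part of what the source reports. "The series", "measured", "known", "first", "only" and "open" are said of these compounds alone.

Compound 1, `Cc1nn(C)c2c1C(c1cccc(Cl)c1)=NCCN2`: 0.63 mg/kg in a functional assay on the whole organism for positive allosteric modulation, with Rattus norvegicus as the target; a higher number here means that more compound is needed for the effect, a lower number that less compound is needed
Compound 2, `Cc1nn(C)c2c1C(c1cccc(Cl)c1)=NCCN2N=O`: 1.25 mg/kg in this assay

Compound 1 has the lowest of the two numbers; its nearest neighbour is compound 2, reached by a 2.0-fold higher number from compound 1 to compound 2 (0.30 log units; within the scatter). Compound 3, `Cc1nn(C)c2c1C(c1cccc(Cl)c1)=NC(C)CN2`, differs from compound 1 by methyl in place of hydrogen on a saturated ring carbon. Among the measured compounds shown here, the single measured step, a 2.0-fold higher number from compound 1 to compound 2 (0.30 log units; within the scatter), concerns a change at another site and lay within the scatter, so nothing in these data speaks for a shift of any size for the methyl. Compound 3 is therefore expected to give about 0.8 mg/kg, in the range 0.3 mg/kg to 2.5 mg/kg, and the expected step of a 1.3-fold higher number from compound 1 to compound 3 (0.10 log units; within the scatter) stays within the scatter.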

Compound 3, minimum effective dose: 0.63 mg/kg
For compound 3 the middle estimate is 1.3-fold (0.10 log units) above the measured one; the range from low to high includes it.
By their numbers in this assay, from the lowest: compounds 1, 3 and 2 (each within the scatter of the next).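

In this assay, among the compounds shown here, methyl in place of hydrogen on a saturated ring carbon gives no change at the digits printed from compound 1 to compound 3 (within the scatter) and so, unlike the earlier step at the ring nitrogen, this is the first reading at this carbon. Compounds 1 and 3 lie within the scatter of each other, so this position accepts a methyl without a step that can be told from the scatter. No measured evidence bears on this result.

Going by these compounds, whether this carbon would equally accept a longer chain such as propyl, or an amine or a carboxylic acid, stays open. So does the effect of a second methyl on the same carbon.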